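Nitro for hydroxy on the aryl hydrazone of compound 1

The compounds below may be only part of what the source reports. "The series", "measured", "known", "first", "only" and "open" are said of these compounds alone.

Among the measured compounds shown here, compound 1 `O=C(COc1cccc2ccccc12)N/N=C/c1cccc(O)c1` sits at the top of the two numbers so far: in an ADME assay on HEL cells (Homo sapiens) for cytotoxicity (on this read-out higher numbers stand for lower toxicity in this test and lower numbers for higher toxicity in this test), compound 1 gives 100 ug/mL. For the measured compounds named here, its nearest neighbour is compound 2 `O=C(COc1cccc2ccccc12)N/N=C/c1ccccc1O`, which in this assay gives 20 ug/mL; the move of the hydroxy group, a 5.0-fold lower number from compound 1 to compound 2 (0.70 log units; beyond the scatter), is the only step measured. Compound 3 `O=C(COc1cccc2ccccc12)N/N=C/c1cccc([N+](=O)[O-])c1` keeps the shared core and changes the ring substituent itself: nitro in place of hydroxy on an aromatic carbon, meta to a large group. Going by the values given here, no measured step involves a nitro group, and the one step known concerns a shift of position rather than an exchange of groups, so it offers only an indirect guide. Among the compounds with values here, the single step was modest in size. Compound 3 is therefore expected to stay close to compound 1, with at most a small drop, a 1.4-fold lower number from compound 1 to compound 3 (0.15 log units; within the scatter), and its estimate in this assay is 70 ug/mL within 20 ug/mL to 100 ug/mL.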

Compound 3, minimum cytotoxic concentration: >= 20 ug/mL
Compound 3: a limit, no number (the forecaster's own chance of this, stated with the estimate: 20%); the middle value is on the limit's open side.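

In this assay compound 3 gives >= 20 ug/mL, which is a limit and not a number. The step from compound 1 to compound 3 therefore cannot be read. The compounds shown leave open how nitro in place of hydroxy on an aromatic carbon shifts this read-out, in size or in direction.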